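Removing the hydroxyl and methyl from the cyclohexyl ring

The compounds below may be only part of what the source reports. "The series", "measured", "known", "first", "only" and "open" are said of these compounds alone.

Measured compounds:
- compound 1 `COc1cc(C(=O)N(C)C)ccc1Nc1nc(OC(C)C)c2cc[nH]c2n1`: 1270 nM
- compound 2 `COc1cc(C(=O)N(C)C)ccc1Nc1nc(O[C@H]2CC[C@](C)(O)CC2)c2cc[nH]c2n1`: 69 nM
- compound 3 `COc1cc(C(=O)N(C)C)ccc1Nc1nc(O[C@H]2CC[C@@](C)(O)CC2)c2cc[nH]c2n1`: 44 nM

In a functional assay on CAL-51 cells (Homo sapiens) for antiproliferative activity, read by luminescence and CellTiter-Glo, with a stated time of 3 days (a lower number here means a stronger inhibitor, a higher number a weaker inhibitor), compound 3 gives the lowest of the three numbers, though the nearest step, a 1.6-fold lower number from compound 2 to compound 3 (0.20 log units; within the scatter), is within the scatter, and the fact that compounds 2 and 3 differ only in the configuration as drawn means the two are mirror images. Compound 4 `COc1cc(C(=O)N(C)C)ccc1Nc1nc(OC2CCCCC2)c2cc[nH]c2n1` changes compound 3 by cyclohexyl in place of 4-hydroxy-4-methylcyclohexyl on an oxygen on an aromatic ring. The measured steps that bear on this are an 18-fold lower number from compound 1 to compound 2 (1.26 log units; beyond the scatter) and a 29-fold lower number from compound 1 to compound 3 (1.46 log units; beyond the scatter), both large, where the 4-hydroxy-4-methylcyclohexyl group entered in place of isopropyl. Compound 4 keeps a six-membered ring but loses the hydroxyl and methyl, so I expect a number between compounds 1 and 3, estimated as a 4.1-fold higher number from compound 3 to compound 4 (0.61 log units; beyond the scatter). For compound 4 in this assay I estimate 180 nM, with a range of 60 nM to 550 nM.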

Compound 4, half-maximal inhibitory concentration: 190 nM
The estimate for compound 4 lay 1.1-fold (0.02 log units) below the measured number, within the range that was stated.
By their numbers in this assay, from the lowest: compounds 3 and 2 (each within the scatter of the next); then compound 4; then compound 1.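

The cyclohexyl ring alone accounts for part of the improvement over isopropyl in this assay, with a 6.7-fold lower number from compound 1 to compound 4 (0.83 log units; beyond the scatter). The hydroxyl and methyl bring a further improvement, since removing them gives a 4.3-fold higher number from compound 3 to compound 4 (0.64 log units; beyond the scatter) and a 2.8-fold higher number from compound 2 to compound 4 (0.44 log units; beyond the scatter). That loss appears with either drawn arrangement of the 4-hydroxy-4-methylcyclohexyl group, so it does not rest on one configuration alone: the fact that compounds 2 and 3 differ only in the configuration as drawn

Which of the hydroxyl and the methyl carries the improvement stays open. So does how a cyclohexyl ring bearing an amine or a carboxylic acid in their place would compare.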